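This account rests on a few compounds, and the source may have more. Where it says the series, first, only, none or still open, it means among the compounds named here.

Measured compounds:
compound 1 `Cc1nc(-c2ccc(Cl)cc2)sc1C(=O)CSc1nc(-c2ccccc2)c(C#N)c(=O)[nH]1` — 83.1%
compound 2 `COc1ccc(-c2nc(C)c(C(=O)CSc3nc(-c4cccc(OC)c4)c(C#N)c(=O)[nH]3)s2)cc1` — 66.7%
compound 3 `COc1ccc(-c2nc(C)c(C(=O)CSc3nc(-c4ccc(OC)c(OC)c4)c(C#N)c(=O)[nH]3)s2)cc1` — 57.6%

In a functional assay on U-87MG ATCC cells for antiproliferative activity against U-87 MG (Homo sapiens), read by MTT assay, with a stated time of 48 h, tested at 10 uM (on this read-out lower numbers stand for a stronger effect and higher numbers for a weaker effect at the one concentration tested), compound 3 gives the lowest of the three numbers. Its nearest neighbour is compound 2, whose value lies within the scatter of compound 3; compound 1 stands further off, beyond the scatter, but compound 1 differs from compound 3 in more than one place, so only the two values themselves can be compared.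

The next compound is compound 4 `COc1ccc(-c2nc(C)c(C(=O)CSc3nc(-c4ccccc4)c(C#N)c(=O)[nH]3)s2)cc1`. It differs from compound 3 as follows: phenyl in place of 3,4-dimethoxyphenyl on an aromatic carbon. Within the data shown here, the one measured step that bears on this change is a number 9.1 percentage points lower from compound 2 to compound 3 (within the scatter), a step of methoxy in place of hydrogen that stayed within the scatter. Compound 4 removes both methoxy groups of compound 3, which runs in the opposite direction of that step and goes one methoxy further. On that basis a modest rise in the read-out is expected for compound 4, of the size a number 12.4 percentage points higher from compound 3 to compound 4 (beyond the scatter), though a result within the scatter of compound 3 would not be surprising. The estimate for compound 4 in this assay is 70%, within a range of 56% to 84%.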

Compound 4, a percentage reported as activity, at one concentration (the size of the read-out at that concentration, not a potency): 90.9%
Beside the measured number, compound 4's estimate is 20.9 percentage points below it, outside the stated range (above it).
By their numbers in this assay, from the lowest: compounds 3 and 2 (each within the scatter of the next); then compounds 1 and 4 (each within the scatter of the next).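

In this assay, this position proves sensitive to its aryl substituents: with phenyl in place of 3,4-dimethoxyphenyl there is a number 33.3 percentage points higher from compound 3 to compound 4 (beyond the scatter), and with hydrogen in place of the single methoxy there is a number 24.2 percentage points higher from compound 2 to compound 4 (beyond the scatter). Among these compounds, both steps point to a weaker effect for the bare phenyl, which the only earlier step at this position, a number 9.1 percentage points lower from compound 2 to compound 3 (within the scatter), could not show, and they indicate that a single methoxy on this phenyl is already enough for a difference beyond the scatter. The exchange of chloro for methoxy at the other changed place gives a number 7.8 percentage points higher from compound 1 to compound 4 (within the scatter), so that pair is not separated, and nothing measured here accounts for any of these differences.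

The compounds shown leave open whether the gain depends on methoxy itself or would also appear with another group on this phenyl, such as hydroxyl, an amine or a carboxylic acid. Going by these compounds, it also remains open whether a longer chain on the oxygen, in place of methoxy, would keep the effect seen for compound 3 at the one concentration tested.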